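One ester group exchanged: compound 2 to compound 3

The source may report more compounds than this note shows. Statements on the series, on what has been measured and on what is new or still open speak of the compounds shown alone.

Compound 1 `N[C@@H](CCC(=O)OC[C@H]1O[C@@H](n2cc(F)c(=O)[nH]c2=O)C[C@@H]1OC(=O)CC[C@H](N)C(=O)O)C(=O)O` with 37300000 nM in the growth assay below
Compound 2 `CC(C)[C@H](N)C(=O)OC[C@H]1O[C@@H](n2cc(F)c(=O)[nH]c2=O)C[C@@H]1O` with 38100000 nM in the growth assay below

In a functional assay on MDA-MB-231 cells (Homo sapiens) for inhibition, read by MTT assay, with a stated time of 24 h (a lower number here means a stronger inhibitor of growth, a higher number a weaker inhibitor of growth), compound 2 gives 38100000 nM and stands level with compound 1 at 37300000 nM within the scatter. Compound 3 `N[C@@H](CCC(=O)OC[C@H]1O[C@@H](n2cc(F)c(=O)[nH]c2=O)C[C@@H]1O)C(=O)O` is still unmeasured and differs from compound 2 in one place: 3-amino-3-carboxypropyl in place of 1-amino-2-methylpropyl on a carbonyl carbon with 3-amino-3-carboxypropyl in place of 1-amino-2-methylpropyl on a carbonyl carbon. Compound 1 also carries 3-amino-3-carboxypropyl on a carbonyl carbon and gives 37300000 nM in this assay so no step beyond the scatter is expected in either direction. The expected step is a 1.1-fold lower number from compound 2 to compound 3 (0.02 log units; within the scatter) and stays within the scatter. For compound 3 the estimate is 36000000 nM with an expected range from 16000000 nM to 80000000 nM around it.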

Compound 3, concentration for 50% growth inhibition: 38300000 nM
The estimate for compound 3 lay 1.1-fold (0.03 log units) below the measured number, within the range that was stated.
By their numbers in this assay, from the lowest: compounds 1, 2 and 3 (each within the scatter of the next).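

In this assay, 3-amino-3-carboxypropyl in place of 1-amino-2-methylpropyl on a carbonyl carbon gives a 1.0-fold higher number from compound 2 to compound 3 (0.00 log units; within the scatter) and so leaves the number unmoved by this exchange of side chains. Hydrogen in place of (3-amino-3-carboxypropyl)carbonyl on an oxygen on a saturated carbon gives a 1.0-fold higher number from compound 1 to compound 3 (0.01 log units; within the scatter) and shows that the second ester makes no readable difference either. No measurement at hand bears on why these numbers stay level. Going by these compounds, it remains open whether an ester with an aromatic ring or a longer carbon chain without the amine would step beyond the scatter.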